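The compounds below may be only part of what the source reports. "The series", "measured", "known", "first", "only" and "open" are said of these compounds alone.

Measured so far:
Compound 1 `O=C(Nc1ccncc1)Nc1ccc(I)cc1` — in a functional assay on the whole organism with Mus musculus as the target, in the maximal electroshock model, with a stated time of 30 min (a lower number here means that less compound is needed, a higher number that more compound is needed for the effect), compound 1 gives > 300 mg/kg, which is a limit of the assay.
Compound 2 `Cc1ccc(NC(=O)Nc2ccncc2)cc1` — in this assay compound 2 gives > 300 mg/kg, also a limit of the assay.

Compound 2 stands at that limit, where both measured values sit: the limit of > 300 mg/kg in this assay, at which 2 of the 2 values shown sit. Among the measured compounds shown here, the one measured step, a step that the two limits leave unreadable from compound 1 to compound 2, has no readable size. Compound 3 `CC(C)c1ccc(NC(=O)Nc2ccncc2)cc1` differs from compound 2 in this way: isopropyl in place of methyl on an aromatic carbon. For the measured compounds named here, no measured step bears on this change with a readable size, so no step beyond the scatter is expected. Compound 3 is expected to give about 300 mg/kg, with a range from 100 mg/kg to 600 mg/kg. The expected step is a number no higher from compound 2 to compound 3 (the limit leaves the size open).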

Compound 3, minimum effective dose: > 300 mg/kg
Compound 3: no number, only a limit; the forecaster's own chance of this, stated with the estimate: 80%; the middle value sits exactly at the limit.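

No step can be read among compound 1, compound 2 and compound 3, because all three stop at the same limit: the limit of > 300 mg/kg in this assay, at which 3 of the 3 values shown sit.

The compounds shown leave open what dose of any of them would give the effect in this assay, and whether the group on the aromatic carbon changes that dose.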